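Series notes: from compound 2 to compound 3

The compounds below may be only part of what the source reports. "The series", "measured", "known", "first", "only" and "open" are said of these compounds alone.

The shared core is that of compound 1 `O=C1NCCN1c1ccc(S(=O)(=O)Nc2ccccc2)cc1`. In a functional assay on HT-29 cells (Homo sapiens) for antiproliferative activity, read by sulforhodamine B assay, with a stated time of 48 h (on this read-out higher numbers stand for weaker inhibition and lower numbers for stronger inhibition), compound 1 gives 280 nM. Compound 2 `CC(C)(C)c1ccc(NS(=O)(=O)c2ccc(N3CCNC3=O)cc2)cc1` carries tert-butyl in place of hydrogen on an aromatic carbon, and in this assay compound 2 gives > 1000 nM, which is a limit of the assay and not a number. The step of an at least 3.5-fold higher number from compound 1 to compound 2 (0.55 log units; beyond the scatter) therefore runs up to the limit (the limit of > 1000 nM in this assay, at which 1 of the 2 values shown sits), so where compound 2 truly stands is open beyond that bound. Compound 3 `CCCCCCOc1ccc(NS(=O)(=O)c2ccc(N3CCNC3=O)cc2)cc1` differs from compound 2 by hexyloxy in place of tert-butyl on an aromatic carbon. Among the compounds with values here, no measured step exchanges one group for another at this position; the only step at hand is an at least 3.5-fold higher number from compound 1 to compound 2 (0.55 log units; beyond the scatter), in which adding a group on this aromatic carbon took the number to the limit. Compound 3 is expected to remain in that weak region, with an estimated step that the limit leaves unreadable from compound 2 to compound 3. In this assay compound 3 is expected to give 2000 nM, probably between 700 nM and 6000 nM.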

Compound 3, half-maximal inhibitory concentration: > 1000 nM
Compound 3 was reported as a limit; the forecaster's own chance of this, stated with the estimate: 70%; the middle value does not contradict the limit.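

In this assay compound 3 gives > 1000 nM, which is a limit of the assay and not a number. Hexyloxy in place of hydrogen on this aromatic carbon gives an at least 3.5-fold higher number from compound 1 to compound 3 (0.55 log units; beyond the scatter), so a second group, unbranched and joined through oxygen, also moves the number away from that of compound 1, as tert-butyl did. The exchange of tert-butyl for hexyloxy cannot be read, and no order between these two groups follows, with compound 2 and compound 3 sharing one bound: the limit of > 1000 nM in this assay, at which 2 of the 3 values shown sit.

Where compound 2 and compound 3 truly stand beyond that bound remains open. Also open, as far as these compounds go, is whether any group on this aromatic carbon keeps the number near the 280 nM of compound 1, for instance fluorine, a methyl group, an amine or a carboxylic acid.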